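The compounds below may be only part of what the source reports. "The series", "measured", "known", "first", "only" and "open" are said of these compounds alone.

Measured so far in a functional assay on PC-3 cells (Homo sapiens) for antiproliferative activity, read by MTT assay, tested at 1 uM; a higher number here means a stronger effect of the compound at the concentration tested, a lower number a weaker effect:
Compound 1 `COc1cc(C2=NN(C(C)=O)C(c3ccc(C(F)(F)F)cc3)O2)cc(OC)c1OC`: -11%
Compound 2 `COc1cc(C2=NN(C(C)=O)C(c3ccccc3F)O2)cc(OC)c1OC`: 13.5%

Within the data shown here, compound 2 stands highest of the two numbers; the only measured step is a number 24.5 percentage points higher from compound 1 to compound 2 (beyond the scatter), a modest rise from changing the aryl group on the saturated ring carbon. Compound 3 `COc1cc(C2=NN(C(C)=O)C(c3ccc(F)c(F)c3)O2)cc(OC)c1OC` differs from compound 2 as follows: 3,4-difluorophenyl in place of 2-fluorophenyl on a saturated ring carbon. Among the measured compounds shown here, that single step concerns the same place, but no measured step goes from 2-fluorophenyl to 3,4-difluorophenyl, so the expectation stays loose. A small step is expected, a number 8.5 percentage points lower from compound 2 to compound 3 (within the scatter), within the scatter. Compound 3 is therefore estimated at 5%, with a range from -15% to 25%.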

Compound 3, a percentage reported as inhibition, at one concentration (the size of the read-out at that concentration, not a potency): 35.5%
Estimate against measurement, compound 3: 30.5 percentage points below; measured number outside the range, above it.
By their numbers in this assay, from the lowest: compound 1; then compound 2; then compound 3.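

On this saturated ring carbon, the choice of aryl group can shift the result in this assay in either direction: a number 22 percentage points higher from compound 2 to compound 3 (beyond the scatter) comes with 3,4-difluorophenyl replacing 2-fluorophenyl, and a number 46.5 percentage points higher from compound 1 to compound 3 (beyond the scatter) comes with it replacing 4-(trifluoromethyl)phenyl. Fluorine-bearing aryl groups at this place therefore do not all give the same result. Nothing at hand explains these gains. As far as these compounds go, how a plain phenyl or a chlorophenyl group would fare at this carbon stays open, as does the effect of a longer acyl chain in place of the acetyl group.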